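Series notes: from compound 3 to compound 4

This account rests on a few compounds, and the source may have more. Where it says the series, first, only, none or still open, it means among the compounds named here.

Measured compounds:
compound 1 `Nc1cc(N)c2nc(-c3ccccc3)c(Oc3ccc(Cl)c(Cl)c3)nc2c1` — < 100000 nM, a limit of the assay
compound 2 `CCOC(=O)[C@H](CCC(=O)O)NC(=O)c1ccc(CNc2nc3cc(N)cc(N)c3nc2-c2ccccc2)cc1` — < 100000 nM, a limit of the assay
compound 3 `Nc1cc(N)c2nc(-c3ccccc3)c(NCc3ccc(Cl)c(Cl)c3)nc2c1` — 67600 nM

Among the compounds with values here, in a functional assay on UACC-62 cells (Homo sapiens) for inhibition, read by sulforhodamine B assay, with a stated time of 48 h (a higher number here means that more compound is tolerated, a lower number that less compound is tolerated), compound 3 stands as the only compound with a number; the other two values rest at the limit of < 100000 nM in this assay, at which 2 of the 3 values shown sit. Compound 4 `COc1ccc(CNc2nc3cc(N)cc(N)c3nc2-c2ccccc2)cc1OC` is not yet measured. It differs from compound 3 by 3,4-dimethoxyphenyl in place of 3,4-dichlorophenyl on a saturated chain carbon bound to a nitrogen on an aromatic ring. Within the data shown here, no step between measured compounds is available, so no direction can be taken from the series; the expected step is a 1.1-fold lower number from compound 3 to compound 4 (0.05 log units; within the scatter), none beyond the scatter. Compound 4 is therefore estimated at 60000 nM, between 25000 nM and 140000 nM.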

Compound 4, concentration lethal to 50% of the cells: 53700 nM
For compound 4 the middle estimate is 1.1-fold (0.05 log units) above the measured one; low and high end bracket the measured number.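

In this assay, within the data shown here, the one step that can be read at this position gives a 1.3-fold lower number from compound 3 to compound 4 (0.10 log units; within the scatter) and so does not separate 3,4-dimethoxyphenyl from 3,4-dichlorophenyl on a saturated chain carbon bound to a nitrogen on an aromatic ring. The exchange adds 2 hydrogen-bond acceptors with no change in the read-out beyond the scatter. No measured property of either group bears on this step.

On these data alone, whether any other group at this place moves the number stays open. Unsubstituted phenyl, a pyridine ring or a longer chain would test this.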